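The source may hold more compounds than are shown below. What is called first, only, known or untested is meant among the compounds shown, and "the series" means these compounds.

In a functional assay on HCT-116 cells (Homo sapiens) for antiproliferative activity, read by MTT assay (a lower number here means a stronger inhibitor, a higher number a weaker inhibitor), two compounds sharing one core have been measured. Compound 1 `Cn1c(=O)c(=O)n(C2CCCC2)c2nc(N/N=C/c3ccccc3)ncc21` reads > 100000 nM, which is a limit of the assay and not a number. Among the measured compounds shown here, compound 2 `Cn1c(=O)c(=O)n(C2CCCC2)c2nc(N/N=C/c3ccc(O)cc3)ncc21` gives 72500 nM, the only true number so far, so it cannot yet be ranked against any other number. For the measured compounds named here, the single measured step, an at least 1.3-fold lower number from compound 1 to compound 2 (0.13 log units; that floor lies within the scatter), places hydroxy in place of hydrogen on an aromatic carbon, and it lies within the scatter. Compound 3 `Cc1cccc(/C=N/Nc2ncc3c(n2)n(C2CCCC2)c(=O)c(=O)n3C)c1` has 3-methylphenyl in place of 4-hydroxyphenyl on a carbon with a double bond to nitrogen. Going by the values given here, the hydroxy group of compound 2 is thus lost, and the only step bearing on that loss is the small one, an at least 1.3-fold lower number from compound 1 to compound 2 (0.13 log units; that floor lies within the scatter), so no change beyond the scatter is expected. For compound 3 the expected value is 90000 nM, with an estimated range of 40000 nM to 150000 nM. This estimate means an expected 1.2-fold higher number from compound 2 to compound 3 (0.09 log units; within the scatter).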

Compound 3, half-maximal inhibitory concentration: > 100000 nM
Compound 3: only a limit was reported (the forecaster's own chance of this, stated with the estimate: 55%); at least 1.1-fold (0.04 log units) between middle value and limit.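

The change from 4-hydroxyphenyl to 3-methylphenyl, on a carbon with a double bond to nitrogen, gives an at least 1.3-fold higher number from compound 2 to compound 3 (0.13 log units; that floor lies within the scatter), so in this assay losing the hydroxy group brings no change that can yet be told from the scatter. The value of compound 3 is a limit and not a number, which leaves the real size of this gap hidden: the limit of > 100000 nM in this assay, at which 2 of the 3 values shown sit. The step linking compound 1 and compound 3 cannot be read, so the methyl group on the phenyl ring shows no measurable effect in either direction.

Still open, going by these compounds, is whether any group on this phenyl ring can bring the number well under that of compound 2, at 72500 nM. An amine, a methoxy group or a carboxylic acid at this ring would test that.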